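A Pentyl Ester Chain on the Free Hydroxy

The compounds below may be only part of what the source reports. "The series", "measured", "known", "first", "only" and "open" are said of these compounds alone.

Three measured compounds share one core and differ only in what sits on one aromatic oxygen. Compound 3 `CC(C)(C)c1cc(-c2cc(=O)c3ccc(O)cc3o2)cc(C(C)(C)C)c1O` carries a free hydroxy there, and in a functional assay for inhibition (a higher number here means a weaker inhibitor, a lower number a stronger inhibitor), compound 3 gives 1000 nM, the lowest number of the three. Compound 1 `CC(C)(C)c1cc(-c2cc(=O)c3ccc(OCC(=O)N4CCN(Cc5ccccc5)CC4)cc3o2)cc(C(C)(C)C)c1O` bears a longer chain ending in a benzylpiperazine amide, and in this assay compound 1 gives 3000 nM. Compound 2 `CC(C)(C)c1cc(-c2cc(=O)c3ccc(OCC(=O)N4CCCCC4)cc3o2)cc(C(C)(C)C)c1O` bears a piperidine amide chain instead, and in this assay compound 2 gives 3000 nM. For the measured compounds named here, the only single-point comparison among them is a 3.0-fold lower number from compound 2 to compound 3 (0.48 log units; beyond the scatter), so removing that chain gave a modestly stronger inhibitor.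

Compound 4 `CCCCCOC(=O)COc1ccc2c(=O)cc(-c3cc(C(C)(C)C)c(O)c(C(C)(C)C)c3)oc2c1` goes the other way: (pentyloxycarbonyl)methyl in place of hydrogen on an oxygen on an aromatic ring. Going by the values given here, no measured step carries exactly this group, but a 3.0-fold lower number from compound 2 to compound 3 (0.48 log units; beyond the scatter) concerns a chain of comparable size attached at the same oxygen, and compound 1, with its own chain there, sits at the same weaker level as compound 2. Compound 4 is therefore expected to lose a modest amount of potency, the expected step being a 2.5-fold higher number from compound 3 to compound 4 (0.40 log units; beyond the scatter). Compound 4 is estimated at 2500 nM, with a likely range from 1000 nM to 6000 nM.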

Compound 4, half-maximal inhibitory concentration: 5000 nM
Compound 4: the middle estimate sits 2.0-fold (0.30 log units) below what was measured; low and high end bracket the measured number.
By their numbers in this assay, from the lowest: compound 3; then compounds 1, 2 and 4 (each within the scatter of the next).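

Placing (pentyloxycarbonyl)methyl on the aromatic oxygen gives a 5.0-fold higher number from compound 3 to compound 4 (0.70 log units; beyond the scatter) in this assay and so shows that an ester chain, and not only an amide chain, goes with a weaker inhibitor than the free hydroxy. Changing only the end of the chain, with pentyloxy in place of piperidin-1-yl on a carbonyl carbon, gives a 1.7-fold higher number from compound 2 to compound 4 (0.22 log units; within the scatter) and so this assay does not separate this ester from this amide. Among compound 2, compound 3 and compound 4, the clear difference therefore lies between having a free hydroxy and having one of these chains on the oxygen, not between the two chain ends. Nothing available here explains why either chain goes with weaker inhibition.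

On these data alone, it remains open whether a much smaller group on this oxygen, such as a methyl, would stay level with the free hydroxy, or whether a chain ending in a carboxylic acid or an amine would behave like the ester and amide chains. As far as these compounds go, how an ethyl ester would compare with the pentyl ester is equally open.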